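The source may report more compounds than this note shows. Statements on the series, on what has been measured and on what is new or still open speak of the compounds shown alone.

In an ADME assay on HeLa cells (Homo sapiens) for cytotoxicity, read by crystal violet staining, with a stated time of 72 h (on this read-out higher numbers stand for lower toxicity in this test and lower numbers for higher toxicity in this test), compound 3 `Cc1cc(-c2noc(C(F)(F)F)n2)cc(C)c1OCCCc1cc(C(=O)OC(C)C)no1` gives 17900 nM and compound 1 `CCOC(=O)c1cc(CCCOc2c(C)cc(-c3noc(C(F)(F)F)n3)cc2C)on1` gives 17200 nM, so these two stand level within the scatter. Compound 2 `CCOC(=O)c1cc(CCCOc2c(OC)cc(-c3noc(C(F)(F)F)n3)cc2[N+](=O)[O-])on1` reads > 100000 nM, which is a limit of the assay and not a number.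

Compound 4 `COc1ccc(-c2cc(CCCOc3c(C)cc(-c4noc(C(F)(F)F)n4)cc3C)on2)cc1OC` differs from compound 3 by a much larger exchange: 3,4-dimethoxyphenyl in place of isopropoxycarbonyl on an aromatic carbon. In short, 3,4-dimethoxyphenyl stands in place of isopropoxycarbonyl on an aromatic carbon. Among the compounds with values here, the only measured step that touches the leaving group is a 1.0-fold higher number from compound 1 to compound 3 (0.02 log units; within the scatter). That step merely puts methyl in place of hydrogen, whereas the entering group brings a six-membered aromatic ring of carbon only, so it offers loose guidance at best. Within the data shown here, no measured compound carries such a ring at this place. The central expectation in this assay is therefore no step beyond the scatter, with real uncertainty in either direction. The estimated step is a 1.1-fold higher number from compound 3 to compound 4 (0.05 log units; within the scatter). Compound 4 is expected at 20000 nM, with an estimated range from 5000 nM to 80000 nM.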

Compound 4, half-maximal cytotoxic concentration: 41900 nM
Estimate against measurement, compound 4: 2.1-fold (0.32 log units) below, and the stated range covers the measured number.
By their numbers in this assay, from the lowest: compounds 1 and 3 (each within the scatter of the next); then compound 4. At a limit, above all of these: compound 2.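

Among the earlier compounds, this position on the five-membered aromatic ring held only esters, and exchanging ethoxycarbonyl for isopropoxycarbonyl gave a 1.0-fold higher number from compound 1 to compound 3 (0.02 log units; within the scatter) in this assay. Placing 3,4-dimethoxyphenyl there moves the read-out beyond the scatter, with a 2.3-fold higher number from compound 3 to compound 4 (0.37 log units; beyond the scatter) and a 2.4-fold higher number from compound 1 to compound 4 (0.39 log units; beyond the scatter). The position therefore accepts a six-membered aromatic ring of carbon only in place of an ester, and the modest shift runs towards lower toxicity in this test.

No measurement shown explains why the number moves with this exchange. As far as these compounds go, it remains open whether an unsubstituted phenyl ring would give a similar step, or whether an amine or a carboxylic acid at this place would shift the number in either direction.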